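Nitro in place of phenyl on the shared core

This account rests on a few compounds, and the source may have more. Where it says the series, first, only, none or still open, it means among the compounds named here.

Compound 1 `C=CC(=O)N1C(=O)CC(c2ccc(Cl)cc2)Sc2ccccc21`: 95700 nM
Compound 2 `C=CC(=O)N1C(=O)CC(c2ccc(-c3ccccc3)cc2)Sc2ccccc21`: 118000 nM

In a functional assay on HL-60 cells (Homo sapiens) for cytotoxicity, read by CCK-8 assay, with a stated time of 24 h (a higher number here means a weaker inhibitor, a lower number a stronger inhibitor), compound 2 gives 118000 nM, which lies within the scatter of compound 1 at 95700 nM. Compound 3 `C=CC(=O)N1C(=O)CC(c2ccc([N+](=O)[O-])cc2)Sc2ccccc21` has not yet been measured. It carries nitro in place of phenyl on an aromatic carbon, para to a large group: nitro in place of phenyl on an aromatic carbon.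

Among the measured compounds shown here, only one measured step bears on this change: a 1.2-fold higher number from compound 1 to compound 2 (0.09 log units; within the scatter), with phenyl in place of chloro at the same place. That step stays within the scatter. A single pair is thin evidence, and nitro has not yet been tested here, but no shift beyond the scatter is expected in this assay. The expected step is a 1.2-fold lower number from compound 2 to compound 3 (0.09 log units; within the scatter). For compound 3 the estimated value is 95000 nM, with an expected range of 40000 nM to 200000 nM.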

Compound 3, half-maximal inhibitory concentration: 107000 nM
The estimate for compound 3 lay 1.1-fold (0.05 log units) below the measured number; the measured number falls inside the stated range.
By their numbers in this assay, from the lowest: compounds 1, 3 and 2 (each within the scatter of the next).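

With nitro on this aromatic carbon, para to a large group, this assay gives a 1.1-fold lower number from compound 2 to compound 3 (0.04 log units; within the scatter) against phenyl and a 1.1-fold higher number from compound 1 to compound 3 (0.05 log units; within the scatter) against chloro. The earlier pair covered only chloro and phenyl, whereas here neither the loss of the aromatic ring nor the entry of two hydrogen-bond acceptors takes the number beyond the scatter, so the three groups cannot be told apart at this place. No evidence on the reason for this is available.

The compounds shown leave open whether any group at this carbon can move the number beyond the scatter, for example an amine or a carboxylic acid. Also open, going by these compounds, is whether other places on the shared core respond in the same way.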